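The source may hold more compounds than are shown below. What is called first, only, known or untested is meant among the compounds shown, and "the series" means these compounds.

Compound 1 `C/C(C#Cc1ccc(CCC(=O)O)c(F)c1)=C/CO` gives 105% in a functional assay on 1321-N1 cells for agonist activity at Free fatty acid receptor 1 (Homo sapiens), read by calcium flux, with a stated time of 0.4 s; a higher number here means a larger maximal response, a lower number a smaller maximal response.
Compound 2 `C/C=C(/C)C#Cc1ccc(CCC(=O)O)c(F)c1` gives 103%.
Compound 3 `O=C(O)CCc1ccc(C#CC2=CCCCC2)cc1` gives 100%.

All three compounds share a core with a propanoic acid chain and carry a triple bond on the aromatic ring, with different small groups hung from that triple bond. Their maximal responses in this assay lie close together: compound 2 sits between compound 1 and compound 3, and both gaps are within the usual scatter of repeated measurements, so the three numbers cannot be told apart.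

Compound 4 `C/C=C/C#Cc1ccc(CCC(=O)O)c(F)c1` differs from compound 2 in a single place: prop-1-en-1-yl in place of 1-methylprop-1-en-1-yl on a triple-bonded carbon. Among the measured compounds shown here, the only measured step that changes one position, a number 2 percentage points lower from compound 1 to compound 2 (within the scatter), alters the same region of the molecule and left the maximal response essentially unchanged. For the measured compounds named here, no measured pair removes a methyl from the double bond as the step to compound 4 does, so that step has no direct precedent. Because compound 1, compound 2 and compound 3 all reach about the same ceiling in this assay despite different groups on the triple-bonded carbon, the expectation is a step of no change at the digits printed from compound 2 to compound 4 (within the scatter), that is none beyond the scatter. Compound 4 is therefore estimated at 103%, with a likely range from 90% to 115%.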

Compound 4, largest response reached (reported as efficacy), in percent of the reference or control that the assay uses: 97%
For compound 4 the middle estimate is 6 percentage points above the measured one; measured number inside the range.
By their numbers in this assay, from the lowest: compounds 4, 3, 2 and 1 (each within the scatter of the next).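

In this assay, putting prop-1-en-1-yl in place of 1-methylprop-1-en-1-yl on a triple-bonded carbon gives a number 6 percentage points lower from compound 2 to compound 4 (within the scatter), so at this position the methyl on the double bond can be removed without a change that rises above the scatter. The larger swap, prop-1-en-1-yl in place of 3-hydroxy-1-methylprop-1-en-1-yl, gives a number 8 percentage points lower from compound 1 to compound 4 (within the scatter), which shows that losing the methyl and the hydroxy together also leaves the maximal response within the scatter, something the earlier step that removed only the hydroxy could not show. No measurement is available that explains these results or links them to any property of the groups.

As far as these compounds go, every group on the triple-bonded carbon in these compounds is built on a carbon-carbon double bond, so it remains open whether that double bond can be replaced, for example by a saturated butyl chain, a phenyl ring or an amine, with the response in this assay holding up. These numbers also describe only the largest response reached, and they say nothing about how much of each compound is needed to reach it.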